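The source may hold more compounds than are shown below. What is called first, only, known or untested is meant among the compounds shown, and "the series" means these compounds.

In a functional assay on CNE-2 cells (Homo sapiens) for inhibition, read by MTT assay, with a stated time of 72 h (on this read-out higher numbers stand for weaker inhibition and lower numbers for stronger inhibition), compound 2 `Nc1nc2cc(-c3nn(CCCCCCCCCC(=O)NO)c4ncnc(N)c34)ccc2o1` gives 36800 nM, the highest of the two actual numbers in the series. Compound 3 `Nc1ncnc2c1c(-c1cnc3[nH]ccc3c1)nn2CCCCCCCCCC(=O)NO` gives 2200 nM. Compound 1 `Nc1nc2cc(-c3nn(CCCC(=O)NO)c4ncnc(N)c34)ccc2o1` gives > 50000 nM, which is a limit and not a number. The change to compound 4 `Nc1nc2cc(-c3nn(CCCCC(=O)NO)c4ncnc(N)c34)ccc2o1` lies in the chain: hydroxycarbamoyl in place of 5-(hydroxycarbamoyl)pentyl on a saturated chain carbon, four bonds along the chain from an aromatic nitrogen. Going by these compounds, the step that bears on this is an at least 1.3-fold lower number from compound 1 to compound 2 (0.13 log units; that floor lies within the scatter), also a change in chain length, and its true size remains open. The step of a 17-fold lower number from compound 2 to compound 3 (1.22 log units; beyond the scatter) replaces the aromatic group and leaves the chain unchanged, so it offers no guide here. A small move to a higher number, not clearly beyond the scatter, is therefore expected in this assay, and the expected step is a 1.4-fold higher number from compound 2 to compound 4 (0.13 log units; within the scatter). The estimate for compound 4 is 50000 nM, with an expected range of 25000 nM to 100000 nM.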

Compound 4, half-maximal inhibitory concentration: > 50000 nM
Compound 4: a limit, no number; the forecaster's own chance of this, stated with the estimate: 55%; the middle value sits exactly at the limit.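

In this assay compound 4 gives > 50000 nM, which is a limit and not a number. Shortening the chain gives an at least 1.3-fold higher number from compound 2 to compound 4 (0.13 log units; that floor lies within the scatter), so this step has only a floor and its true size stays open. The step between the two short-chain compounds, compound 1 and compound 4, cannot be read, as both stop at the same limit: the limit of > 50000 nM in this assay, at which 2 of the 4 values shown sit.

Open, going by these compounds, is where a chain of intermediate length, ending in hydroxycarbamoyl, would fall on the shared core. Also open, on these data alone, is what a carboxylic acid in place of the hydroxycarbamoyl end would give on the chain of compound 2.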